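The source may report more compounds than this note shows. Statements on the series, on what has been measured and on what is new or still open speak of the compounds shown alone.

Measured compounds:
compound 1 `CCOC(=O)c1c(-c2ccc(Cl)cc2)cc(-c2ccccc2)nc1N1CCCCC1`: 70.1%
compound 2 `CCOC(=O)c1c(-c2ccc(Cl)c(Cl)c2)cc(-c2ccccc2)nc1N1CCCCC1`: 64.7%

Of the compounds shown here, two have been tested in a functional assay on the whole organism (strain Wister albino) for inhibition, with Rattus norvegicus as the target, read by paw edema, with stated times of 1 h and 4 h, at a dose of 50 mg/kg by the intraperitoneal route; on this read-out higher numbers stand for more inhibition at the one dose given (going by the name of the read-out) and lower numbers for less inhibition. Compound 1 gives 70.1% in this assay, and compound 2 gives 64.7%. For the measured compounds named here, the only measured step, a number 5.4 percentage points lower from compound 1 to compound 2 (within the scatter), lies within the scatter, so nothing separates these two numbers; compound 1 simply has the one that reads a little higher on paper.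

The next compound, compound 3 `CCOC(=O)c1c(-c2ccc(Cl)cc2)cc(-c2ccccc2)nc1N1CCN(C)CC1`, departs from compound 1 in a different way: 4-methylpiperazin-1-yl in place of piperidin-1-yl on an aromatic carbon. Going by the values given here, no measured step concerns this part of the shared core, since the step from compound 1 to compound 2 involves only a chloro entering in place of hydrogen. There is therefore no measured guide to how exchanging piperidin-1-yl for 4-methylpiperazin-1-yl will read out, and the prudent expectation is a step of no more than the scatter in either direction.

Compound 3 is accordingly estimated at 65% in this assay, with a range from 45% to 80%. This estimate means an expected step of a number 5.1 percentage points lower from compound 1 to compound 3 (within the scatter), which is not beyond the scatter.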

Compound 3, a percentage reported as inhibition, in the whole organism at one dose (the size of the read-out at that dose, not a potency): 37.8%
Estimate against measurement, compound 3: 27.2 percentage points above; the measured number lies below the stated range.
By their numbers in this assay, from the lowest: compound 3; then compounds 2 and 1 (each within the scatter of the next).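

In this assay, for the compounds shown here, this position, on an aromatic carbon next to the ring nitrogen, is the first place where a single change goes beyond the scatter (a number 32.3 percentage points lower from compound 1 to compound 3 (beyond the scatter)), whereas the chloro change on the aromatic ring stayed within it (a number 5.4 percentage points lower from compound 1 to compound 2 (within the scatter)). The ring stays six-membered and non-aromatic and no net charge appears, yet 4-methylpiperazin-1-yl, with its 2 hetero atoms, reads far lower than piperidin-1-yl, with its 1 hetero atom, so the inhibition read here is sensitive to what this ring carries, at least in this one pair. Nothing available explains why the number drops with this exchange.

As far as these compounds go, what stays open is whether the extra ring nitrogen or the methyl group on it goes with the lower number, a question that piperazin-1-yl with a hydrogen on that nitrogen, or morpholin-4-yl with a ring oxygen in its place, could help to answer. From the compounds shown here alone, it also remains open whether the same exchange would read the same way on the core of compound 2, or whether a simple open-chain amine such as diethylamino would behave more like piperidin-1-yl at this position.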